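This account rests on a few compounds, and the source may have more. Where it says the series, first, only, none or still open, it means among the compounds named here.

In an ADME assay on MT2 cells (Homo sapiens) for cytotoxicity, read by XTT assay, with a stated time of 4 days (on this read-out lower numbers stand for higher toxicity in this test and higher numbers for lower toxicity in this test), compound 1 `COC(=O)c1ccc(-c2noc(CCl)n2)cc1` gives 14200 nM. Among the three measured compounds this is the lowest number: compound 3 `O=C(O)c1ccc(-c2noc(CCl)n2)cc1` gives 64000 nM, and compound 2 `O=C(O)c1ccc(-n2cccc2)cc1` gives 535000 nM. The one measured step that links two of these compounds directly is a 4.5-fold higher number from compound 1 to compound 3 (0.65 log units; beyond the scatter), which concerns the ester end of the shared core and not the halomethyl group.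

Compound 4 `COC(=O)c1ccc(-c2noc(CBr)n2)cc1` differs from compound 1 by bromo in place of chloro on a saturated chain carbon bound to an aromatic carbon. Among the measured compounds shown here, no measured step touches this part of the molecule, so the step from compound 1 to compound 3 offers no guidance on the size or direction of the change, and the gap between compound 1 and compound 2 reflects a different replacement altogether. The expectation therefore rests on the exchange of one halogen for another at the same place, and the estimated change is small: compound 4 is expected to give 10000 nM, within a range of 3000 nM to 30000 nM, which corresponds to an estimated step of a 1.4-fold lower number from compound 1 to compound 4 (0.15 log units; within the scatter).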

Compound 4, half-maximal cytotoxic concentration: 32700 nM
The estimate for compound 4 lay 3.3-fold (0.51 log units) below the measured number; measured number above the stated range.
By their numbers in this assay, from the lowest: compound 1; then compounds 4 and 3 (each within the scatter of the next); then compound 2.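

The exchange of chloro for bromo on a saturated chain carbon bound to an aromatic carbon gives a 2.3-fold higher number from compound 1 to compound 4 (0.36 log units; beyond the scatter) in this assay. Among the compounds shown here, this shows that the number responds to the identity of the halogen at this place, a part of the molecule that no earlier step had touched, and that bromo moves it toward lower toxicity in this test. Nothing at hand accounts for the direction or size of this step.

The compounds shown leave open whether the same exchange would act in the same direction with the carboxylic acid of compound 3 in place of the ester. They also leave open what an iodomethyl group would give at this place, and whether an amine or a hydroxyl group in place of the halogen would keep the number near that of compound 1.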